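The source may hold more compounds than are shown below. What is called first, only, known or untested is meant among the compounds shown, and "the series" means these compounds.

Three compounds share one core and differ only in the group sitting on a saturated chain carbon bound to an oxygen on a saturated carbon. Compound 1 `N[C@]1(C(=O)O)[C@H]2[C@@H](C[C@H]1OCc1cccc(Cl)c1)[C@]2(F)C(=O)O` carries a 3-chlorophenyl there, and in an assay on CHO cells for binding affinity to metabotropic glutamate receptor 2 (Rattus norvegicus) (a lower number here means a stronger inhibitor, a higher number a weaker inhibitor), compound 1 gives 3.28 nM. Compound 2 `N[C@]1(C(=O)O)[C@H]2[C@@H](C[C@H]1OCc1ccc(F)c(F)c1)[C@]2(F)C(=O)O` carries a 3,4-difluorophenyl, and in this assay compound 2 gives 2.27 nM. Compound 3 `N[C@]1(C(=O)O)[C@H]2[C@@H](C[C@H]1OC(c1ccc(Cl)c(Cl)c1)c1ccc(Cl)c(Cl)c1)[C@]2(F)C(=O)O` carries 3,4-dichlorophenyl groups, and in this assay compound 3 gives 2.61 nM. Compound 2 has the lowest of the three numbers, yet the differences are small: the step of a 1.4-fold lower number from compound 1 to compound 2 (0.16 log units; within the scatter), and the values of compound 2 and compound 3 lie within the scatter of each other, so none of the three can be called stronger than another.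

Compound 4 `N[C@]1(C(=O)O)[C@H]2[C@@H](C[C@H]1OCc1cccs1)[C@]2(F)C(=O)O` has not yet been measured. It differs from compound 2 in one place: thiophen-2-yl in place of 3,4-difluorophenyl on a saturated chain carbon bound to an oxygen on a saturated carbon. Among the compounds with values here, the only measured step that bears on this change is the exchange of one aromatic group for another at the same place, a 1.4-fold lower number from compound 1 to compound 2 (0.16 log units; within the scatter), which stayed within the scatter. Nothing shown here suggests that swapping the aromatic group at this place shifts the number beyond the scatter, so for compound 4 in this assay a step of a 1.2-fold higher number from compound 2 to compound 4 (0.09 log units; within the scatter) is expected, inside the scatter. The estimate for compound 4 is 2.8 nM, with a range from 1.2 nM to 6.5 nM.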

Compound 4, inhibition constant: 8.79 nM
The estimate for compound 4 lay 3.1-fold (0.50 log units) below the measured number, and the stated range ends below it.
By their numbers in this assay, from the lowest: compounds 2, 3 and 1 (each within the scatter of the next); then compound 4.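

The one exchange among phenyl groups with a listed step, a 1.4-fold lower number from compound 1 to compound 2 (0.16 log units; within the scatter), stayed within the scatter in this assay, which made this place look tolerant of a change of aromatic group. Thiophen-2-yl shows that this tolerance has a limit, since the number rises beyond the scatter against both phenyl compounds, with a 3.9-fold higher number from compound 2 to compound 4 (0.59 log units; beyond the scatter) and a 2.7-fold higher number from compound 1 to compound 4 (0.43 log units; beyond the scatter), although both steps are only modest. Nothing available here accounts for the rise with this change.

This single exchange alters several things at once: the ring goes from six members to five, a sulfur enters the ring and the halogens leave, so the compounds shown cannot tell which of these goes with the higher number; an unsubstituted phenyl, a thiophen-3-yl or a furan-2-yl at the same place would help to separate them. On these data alone, it also remains open whether an aromatic ring is needed here at all, for example whether a cyclohexyl group or a short chain ending in an amine on a saturated chain carbon bound to an oxygen on a saturated carbon would keep the number close to these values.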